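A few compounds are considered here, and "the series" means these few. Any claim that something is new, unique, unknown or untested is made for them only; others in the source may bear on it.

Compound 1 `COc1ccc(N2CCN(C3=CC(=O)c4ccccc4C3=O)CC2)cc1` gives the highest number of the two measured in a functional assay on DU-145 cells (Homo sapiens) for inhibition, read by MTT assay, with a stated time of 72 h (on this read-out higher numbers stand for weaker inhibition and lower numbers for stronger inhibition), at 46100 nM. Compound 2 `Cc1cccc(N2CCN(C3=CC(=O)c4ccccc4C3=O)CC2)c1` in this assay gives 7400 nM, a change of a 6.2-fold lower number from compound 1 to compound 2 (0.79 log units; beyond the scatter). Compound 3 `COc1ccccc1N1CCN(C2=CC(=O)c3ccccc3C2=O)CC1` differs from compound 1 by 2-methoxyphenyl in place of 4-methoxyphenyl on an amine nitrogen in a ring. Among the compounds with values here, the one measured step touches the same place but exchanges a different group, so it bears only loosely on this change; its size suggests the ring nitrogen substituent can shift the number substantially. The expected step is a 2.6-fold lower number from compound 1 to compound 3 (0.41 log units; beyond the scatter), a moderate lowering with wide uncertainty. Compound 3 is therefore estimated at 18000 nM, in the range 5000 nM to 70000 nM.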

Compound 3, half-maximal inhibitory concentration: 8000 nM
Estimate against measurement, compound 3: 2.3-fold (0.35 log units) above, within the range that was stated.
By their numbers in this assay, from the lowest: compounds 2 and 3 (each within the scatter of the next); then compound 1.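

In this assay, 2-methoxyphenyl in place of 4-methoxyphenyl, the same atoms joined differently, gives a 5.8-fold lower number from compound 1 to compound 3 (0.76 log units; beyond the scatter) and so shows that where the methoxy group sits on this phenyl ring moves the number by itself. Exchanging 3-methylphenyl for 2-methoxyphenyl gives a 1.1-fold higher number from compound 2 to compound 3 (0.03 log units; within the scatter) and leaves these two groups not told apart here. Nothing at hand accounts for either step. The compounds shown leave open how 3-methoxyphenyl would compare, and whether an amine or a carboxylic acid on this phenyl ring would keep the lower numbers.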